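Trimming the Side Chain in a Purine Amide Series

The compounds below may be only part of what the source reports. "The series", "measured", "known", "first", "only" and "open" are said of these compounds alone.

Of the compounds shown here, two built on a shared core have been measured so far. Compound 1 `O=C(O)[C@@H]1CCCN1C(=O)CN(c1nc(Cl)nc2[nH]cnc12)C1CC1` carries a cyclic amino acid on the amide, and in a functional assay on the whole organism (Tail, strain ICR) with Mus musculus as the target, in the tail flick test, with a stated time of 120 min, at a dose of 25 umol/kg by the oral route (on this read-out lower numbers stand for a weaker effect and higher numbers for a stronger effect at the one dose given), compound 1 gives 23.6%. Compound 2 `NCCCC[C@H](NC(=O)CN(c1nc(Cl)nc2[nH]cnc12)C1CC1)C(=O)O` carries an open-chain amino acid in its place, and in this assay compound 2 gives 16.4%. Going by the values given here, these are the only two numbers available, and the value of compound 1 lies within the scatter of that of compound 2, so the two cannot be told apart on this read-out; both sit at a modest level.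

Compound 3 `C[C@H](NC(=O)CN(c1nc(Cl)nc2[nH]cnc12)C1CC1)C(=O)O` has not yet been measured. Relative to compound 2 it differs by hydrogen in place of 3-aminopropyl on a saturated chain carbon, two bonds along the chain from an amide-type nitrogen and a carbonyl carbon. Among the compounds with values here, no measured pair shows the effect of such a change, so the account can only lean on the two values at hand, which themselves do not separate. The step from compound 2 to compound 3 is therefore expected to be a number 1.6 percentage points higher from compound 2 to compound 3 (within the scatter), that is, nothing beyond the scatter in either direction. On this basis compound 3 is estimated to reach 18%, with a plausible range from 5% to 35%.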

Compound 3, a percentage reported as activity, at one dose (the size of the read-out at that dose, not a potency): 28.4%
Estimate against measurement, compound 3: 10.4 percentage points below; the measured number falls inside the stated range.
By their numbers in this assay, from the lowest: compounds 2, 1 and 3 (each within the scatter of the next, the first and the last beyond it).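

Going by these compounds alone, replacing 3-aminopropyl with hydrogen on the saturated chain carbon, two bonds along the chain from an amide-type nitrogen and a carbonyl carbon, gives the first step in this assay that clears the scatter, a number a number 12 percentage points higher from compound 2 to compound 3 (beyond the scatter), so the long 4-aminobutyl side chain of compound 2 is not required for the effect at this position, and the methyl of compound 3 gives more. The acyclic and cyclic amino acids still cannot be told apart, with a number 4.8 percentage points higher from compound 1 to compound 3 (within the scatter) lying within the scatter, so (1-carboxyethyl)amino and 2-carboxypyrrolidin-1-yl on the carbonyl carbon read alike here. Nothing among the data at hand offers an explanation for the step from the long side chain to the short one.

From the compounds shown here alone, what stays open is whether the amine of the side chain or the length of the chain accounts for the step, a question that a plain butyl chain on the same carbon would separate. Also open, going by these compounds, is how much the carboxylic acid contributes, which a methyl ester or a primary amide in its place would show.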